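Vinyl sulfone series: indole in place of nitrothiophene

A few compounds are considered here, and "the series" means these few. Any claim that something is new, unique, unknown or untested is made for them only; others in the source may bear on it.

Three compounds of the series have numbers in a functional assay on DU-145 cells (Homo sapiens) for inhibition, read by trypan blue exclusion, with a stated time of 96 h; on this read-out higher numbers stand for weaker inhibition of growth and lower numbers for stronger inhibition of growth. Compound 1 `Cc1ccc(S(=O)(=O)/C(=C/c2ccc(C)s2)C(=O)c2ccc(Cl)cc2)cc1` gives 50000 nM in this assay. Compound 3 `CCOc1ccc(/C=C(\C(=O)c2ccc(Br)cc2)S(=O)(=O)c2ccc(Br)cc2)c(OCC)c1` gives 10000 nM in this assay. Compound 2 `O=C(/C(=C\c1csc([N+](=O)[O-])c1)S(=O)(=O)c1ccc(Br)cc1)c1ccc(Br)cc1` gives 1000 nM in this assay, the lowest of the three numbers; its gap to compound 3 and its larger gap to compound 1 both lie beyond the usual scatter, so compound 2 is the strongest inhibitor of growth among the measured set. Within the data shown here, no two measured compounds differ in only one place, so no single-change step is available from the data.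

Compound 4 `O=C(/C(=C\c1c[nH]c2ccccc12)S(=O)(=O)c1ccc(Br)cc1)c1ccc(Br)cc1` has not yet been measured. Its relation to compound 2 is 1H-indol-3-yl in place of 5-nitrothiophen-3-yl on a double-bonded chain carbon bound to a double-bonded chain carbon. The shared core is untouched; the change trades one five-membered aromatic ring with 1 hetero atom and 3 hydrogen-bond acceptors for a group with 1 hydrogen-bond donor and a second, six-membered aromatic ring of carbon only. Among the measured compounds shown here, no measured pair covers such a swap. Since compound 2 alone reaches a low number while every other group tried gives a higher one, a weakening beyond the scatter, yet smaller than the gap to compound 3, is expected as the step of a 3.0-fold higher number from compound 2 to compound 4 (0.48 log units; beyond the scatter) in this assay. Compound 4 is expected to give 3000 nM in this assay, within 600 nM to 15000 nM.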

Compound 4, concentration for 50% growth inhibition: 25000 nM
Beside the measured number, compound 4's estimate is 8.3-fold (0.92 log units) below it; measured number above the stated range.
By their numbers in this assay, from the lowest: compound 2; then compound 3; then compounds 4 and 1 (each within the scatter of the next).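

In this assay, putting 1H-indol-3-yl in place of 5-nitrothiophen-3-yl on a double-bonded chain carbon bound to a double-bonded chain carbon gives a 25-fold higher number from compound 2 to compound 4 (1.40 log units; beyond the scatter). Among these compounds, this is the first single-change step, and it shows that with the shared core untouched, the group at this place alone can decide whether the low number of compound 2 is kept, so the core by itself does not secure it. Nothing measured explains the size of this step.

The change removes the nitro group and the sulfur-containing ring while adding a hydrogen-bond donor and a six-membered aromatic ring of carbon only, and this one step cannot separate these contributions. A plain thiophen-3-yl group at the same place would test the weight of the nitro group, a 5-cyanothiophen-3-yl group would test whether another substituent can stand in for it, and a 1H-indol-3-yl group carrying a nitro group would test whether the second ring can be tolerated once the nitro group is present.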